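The source may hold more compounds than are shown below. What is called first, only, known or untested is meant among the compounds shown, and "the series" means these compounds.

Among the measured compounds shown here, in a functional assay on LNCaP cells (Homo sapiens) for cytotoxicity (a lower number here means a stronger inhibitor, a higher number a weaker inhibitor), compound 1 `CNC(=O)Nc1ccc(-c2nc(N3CC4CCC(C3)O4)c3cnn(C)c3n2)cc1` gives 170 nM, the highest number of the three measured so far. Compound 2 `O=C(Nc1ccccc1)Nc1ccc(-c2nc(N3CC4CCC(C3)O4)c3cnn(C4CCC5(CC4)OCCO5)c3n2)cc1` gives 4 nM, and compound 3 `CCNC(=O)Nc1ccc(-c2nc(N3CC4CCC(C3)O4)c3cnn(C4CCC5(CC4)OCCO5)c3n2)cc1` gives 1 nM. Both of these carry a larger group than methyl on the aromatic nitrogen, and both also differ from compound 1 at the urea end, so their values cannot be credited to one change alone.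

The next compound, compound 4 `CNC(=O)Nc1ccc(-c2nc(N3CC4CCC(C3)O4)c3cnn([C@H]4CC[C@@H](O)CC4)c3n2)cc1`, keeps the rest of compound 1 and makes a single change: 4-hydroxycyclohexyl in place of methyl on an aromatic nitrogen.

For the measured compounds named here, only one measured step changes a single place, a 4.0-fold lower number from compound 2 to compound 3 (0.60 log units; beyond the scatter). It is modest but beyond the scatter, and it concerns ethyl in place of phenyl on an amide-type nitrogen, so it shows only that the other end of these molecules also moves the number. Going by the values given here, no measured pair isolates the change made here, and no measured compound carries the hydroxyl group.

The low values of compound 2 at 4 nM and compound 3 at 1 nM still suggest that a larger group on this nitrogen goes with a lower number. The expected change is therefore a clear drop, estimated as a 21-fold lower number from compound 1 to compound 4 (1.33 log units; beyond the scatter). Compound 4 is estimated at 8 nM, with an expected range from 2 nM to 40 nM.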

Compound 4, half-maximal inhibitory concentration: 20 nM
Beside the measured number, compound 4's estimate is 2.5-fold (0.40 log units) below it; the measured number falls inside the stated range.
By their numbers in this assay, from the lowest: compound 3; then compound 2; then compound 4; then compound 1.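

Compound 4 keeps the methyl urea and the rest of compound 1, so the change on the aromatic nitrogen can be read alone, and in this assay it gives an 8.5-fold lower number from compound 1 to compound 4 (0.93 log units; beyond the scatter). Among the compounds shown here, this is the first measured pair to show that this position by itself moves the number, something compounds 2 and 3 could not show, since each differs from compound 1 at the urea end as well. It also shows that a group carrying a six-membered carbon ring and a hydroxyl is accepted here in place of a single methyl, with the number falling rather than rising, though nothing measured in this set explains the drop.

As far as these compounds go, the ring and the hydroxyl enter together, so their separate shares remain unknown, and a plain cyclohexyl group would be needed to divide them, while a 4-aminocyclohexyl group would test whether the oxygen can give way to a nitrogen. Also open, from the compounds shown here alone, is how the opposite arrangement of the hydroxyl on the ring would compare, along with whether a methyl urea paired with the ketal-bearing ring of compounds 2 and 3 would behave like those compounds.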